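The source may report more compounds than this note shows. Statements on the series, on what has been measured and on what is new or still open speak of the compounds shown alone.

Among the compounds with values here, only two compounds with the shared core have numbers so far. In a functional assay on L1210 cells (Mus musculus) for inhibition (on this read-out lower numbers stand for stronger inhibition and higher numbers for weaker inhibition), compound 1 (`O=C1CCCCC/C1=C\c1ccc(F)cc1`) gives 291000 nM, and compound 2 (`O=C1CCCCC/C1=C\c1cccc([N+](=O)[O-])c1`) gives 162000 nM. These values lie within the usual scatter of each other, so the data do not separate the two compounds.

Compound 3 (`CN(C)c1ccc(/C=C2\CCCCCC2=O)cc1`) has not yet been measured. It keeps the core of compound 1 but carries dimethylamino in place of fluoro on an aromatic carbon, para to a group of 9 heavy atoms (dimethylamino in place of fluoro on an aromatic carbon).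

Within the data shown here, no measured pair shows this exact swap, so there is no direct guide to its effect. Among the measured compounds shown here, the only comparison available is indirect: compound 2, at 162000 nM, has a different group on the aromatic ring and still falls within the scatter of compound 1. On that limited evidence, no step beyond the scatter is expected in this assay, with a slight lean towards a lower number. The expected step is a 1.8-fold lower number from compound 1 to compound 3 (0.26 log units; within the scatter). Compound 3 is estimated at 160000 nM, with an expected range from 50000 nM to 400000 nM.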

Compound 3, half-maximal inhibitory concentration: 79100 nM
For compound 3 the middle estimate is 2.0-fold (0.31 log units) above the measured one, and the stated range covers the measured number.
By their numbers in this assay, from the lowest: compound 3; then compounds 2 and 1 (each within the scatter of the next).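

In this assay, the aromatic carbon that carries fluoro in compound 1 proves sensitive to what sits there: putting dimethylamino in place of fluoro gives a 3.7-fold lower number from compound 1 to compound 3 (0.57 log units; beyond the scatter). Within the data shown here, this is the first step in the set that clearly exceeds the usual scatter, so a single change at this place, para to a group of 9 heavy atoms, can move the read-out towards stronger inhibition, although compound 3 still gives 79100 nM. The data offer no measurement that explains this gain.

Among these compounds, with only one swap at this place, it remains open whether the gain is specific to dimethylamino or would also appear with a plain amine, a methoxy group or a diethylamino group. It is also unclear whether dimethylamino would give a similar step at another carbon of the aromatic ring, or whether further gains could come from changes elsewhere on the shared core.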